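A few compounds are considered here, and "the series" means these few. Any claim that something is new, unique, unknown or untested is made for them only; others in the source may bear on it.

Compound 1 `O=C(O)c1ccc2c(c1)no[n+]2[O-]`: "not determined" (no result reported)
Compound 2 `O=C(CCCOC(=O)c1ccc2c(c1)no[n+]2[O-])NO`: 6580 nM

The measurements come from a functional assay on PC-3 cells (Homo sapiens) for inhibition, read by MTT assay, with a stated time of 48 h (a higher number here means a weaker inhibitor, a lower number a stronger inhibitor), and leave little to compare. Within the data shown here, compound 2 holds the only number available, since compound 1 gave no result, so its standing can't be judged against any measured neighbour. Compound 3 `O=C(CCCCCOC(=O)c1ccc2c(c1)no[n+]2[O-])NO` keeps the core of compound 1 and carries a longer chain, with the change 2-(hydroxycarbamoyl)ethyl in place of hydroxycarbamoyl on a saturated chain carbon, three bonds along the chain from an oxygen next to a carbonyl group on the chain of compound 2. Here 2-(hydroxycarbamoyl)ethyl stands in place of hydroxycarbamoyl on a saturated chain carbon, three bonds along the chain from an oxygen next to a carbonyl group. Among the measured compounds shown here, no measured step shows what such a change does in this assay, so any forecast is tentative. A modestly lower number, meaning a stronger inhibitor, is expected, and the expected step of a 2.2-fold lower number from compound 2 to compound 3 (0.34 log units; beyond the scatter) may not stand far beyond the scatter. For compound 3 the estimated value is 3000 nM, with an expected range from 800 nM to 9000 nM.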

Compound 3, half-maximal inhibitory concentration: 12400 nM
Compound 3: middle estimate off by 4.1-fold (0.62 log units), on the low side; the whole stated range lies below it.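

In this assay, the move from hydroxycarbamoyl to 2-(hydroxycarbamoyl)ethyl on a saturated chain carbon, three bonds along the chain from an oxygen next to a carbonyl group, gives a 1.9-fold higher number from compound 2 to compound 3 (0.28 log units; within the scatter). Among these compounds, this is the first measured step, and it leaves the two compounds indistinguishable, so this change in chain length has no effect at this position that the assay can separate from the scatter. Nothing available here bears on why the result came out this way.

Still open, from the compounds shown here alone, is whether a longer chain at this place, such as 5-(hydroxycarbamoyl)pentyl, would separate from compound 2 beyond the scatter. Also open, going by these compounds, is what a primary amide or an amine would do in place of the hydroxycarbamoyl end.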